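Chain and aryl variation in a thromboxane receptor series

This account rests on a few compounds, and the source may have more. Where it says the series, first, only, none or still open, it means among the compounds named here.

Measured so far in a functional assay on a cell-free system (plasma) for inhibition of thromboxane A2 receptor (Homo sapiens), read by turbidimetry; on this read-out lower numbers stand for stronger inhibition and higher numbers for weaker inhibition:
compound 1 `O=C(O)COCCCC[C@H]1[C@H](F)CC[C@@H]1NS(=O)(=O)c1ccc(F)cc1` gives 1800 nM
compound 2 `O=C(O)CC/C=C\C[C@H]1[C@H](F)CC[C@@H]1NS(=O)(=O)c1ccc(F)cc1` gives 750 nM
compound 3 `Cc1ccc(S(=O)(=O)N[C@H]2CC[C@@H](F)[C@@H]2CCCCOCC(=O)O)cc1` gives 1800 nM

Compound 2 differs from compound 1 by 4-carboxybut-1-en-1-yl in place of 3-(carboxymethoxy)propyl on a saturated chain carbon bound to a saturated ring carbon; the step is a 2.4-fold lower number from compound 1 to compound 2 (0.38 log units; beyond the scatter). Compound 3 differs from compound 1 by methyl in place of fluoro on an aromatic carbon; the step is no change at the digits printed from compound 1 to compound 3 (within the scatter), so the two cores sit level in this assay. Compound 4 `Cc1ccc(S(=O)(=O)N[C@H]2CC[C@@H](F)[C@@H]2C/C=C\CCC(=O)O)cc1` is unmeasured. It stands to compound 3 as compound 2 stands to compound 1, by 4-carboxybut-1-en-1-yl in place of 3-(carboxymethoxy)propyl on a saturated chain carbon bound to a saturated ring carbon, the same change at the same place on the other core. In this assay the step from compound 3 to compound 4 is expected to be a 2.4-fold lower number from compound 3 to compound 4 (0.38 log units; beyond the scatter), because the same change gave a 2.4-fold lower number from compound 1 to compound 2 (0.38 log units; beyond the scatter). Compound 4 is therefore estimated at 750 nM, expected between 350 nM and 1600 nM.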

Compound 4, half-maximal inhibitory concentration: 1900 nM
For compound 4 the middle estimate is 2.5-fold (0.40 log units) below the measured one; measured number above the stated range.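

In this assay the chain change gives a 1.1-fold higher number from compound 3 to compound 4 (0.02 log units; within the scatter), while methyl in place of fluoro on an aromatic carbon, with the 4-carboxybut-1-en-1-yl chain in place, gives a 2.5-fold higher number from compound 2 to compound 4 (0.40 log units; beyond the scatter). The lower number seen on the core of compound 1 does not recur on the core of compound 3, yet the gap between the two steps cannot be called a real difference: the same change on two cores in this assay, a 2.4-fold lower number (0.38 log units; beyond the scatter) from compound 1 to compound 2 and a 1.1-fold higher number (0.02 log units; within the scatter) from compound 3 to compound 4, 2.5-fold (0.40 log units) apart, within the scatter of two such steps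
Read from the aryl side, the result is the same, so these four compounds neither show that the chain change carries between cores nor show that it fails to: the same change on two cores in this assay, no change at the digits printed (within the scatter) from compound 1 to compound 3 and a 2.5-fold higher number (0.40 log units; beyond the scatter) from compound 2 to compound 4, 2.5-fold (0.40 log units) apart, within the scatter of two such steps

From the compounds shown here alone, it remains open how the chain change reads with chloro or methoxy on that aromatic carbon. Going by these compounds, a longer chain ending in the carboxylic acid also remains open.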